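Trifluoromethylphenyl replaces fluorophenyl on compound 2's core

The source may report more compounds than this note shows. Statements on the series, on what has been measured and on what is new or still open speak of the compounds shown alone.

Compound 2 `Oc1ccc(-c2cc(-c3ccccc3F)cc(-c3ccccc3O)n2)cc1` carries a 2-fluorophenyl group and two hydroxyphenyl groups on a shared core. In a functional assay on DU-145 cells (Homo sapiens) for inhibition (on this read-out higher numbers stand for weaker inhibition and lower numbers for stronger inhibition), compound 2 gives only a limit, > 50000 nM. Compound 1 `Oc1ccccc1-c1cc(-c2ccccc2F)cc(-c2ccccc2O)n1` also gives only a limit in this assay, > 50000 nM. Compound 3 `Oc1ccc(-c2cc(-c3ccccc3F)cc(-c3ccc(O)cc3)n2)cc1` gives 7780 nM in this assay. The step that the two limits leave unreadable from compound 1 to compound 2 is unreadable because the limit of > 50000 nM in this assay, at which 2 of the 3 values shown sit, holds both values. The step of an at least 6.4-fold lower number from compound 2 to compound 3 (0.80 log units; beyond the scatter) concerns a hydroxyphenyl group, not the fluorophenyl. Compound 4 `Oc1ccc(-c2cc(-c3ccc(C(F)(F)F)cc3)cc(-c3ccccc3O)n2)cc1` differs from compound 2 by 4-(trifluoromethyl)phenyl in place of 2-fluorophenyl on an aromatic carbon. Within the data shown here, no measured step touches this group, so no size can be drawn from them. The writer therefore expects compound 4 to give about 50000 nM, between 10000 nM and 200000 nM, an expected step of a number no higher from compound 2 to compound 4 (the limit leaves the size open) within the scatter.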

Compound 4, half-maximal inhibitory concentration: > 50000 nM
Compound 4 was reported as a limit (the forecaster's own chance of this, stated with the estimate: 60%); the middle value lies on the limit itself.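

No step can be read between compound 2 and compound 4, because both rest on the same limit: the limit of > 50000 nM in this assay, at which 3 of the 4 values shown sit.

Going by these compounds, how far 4-(trifluoromethyl)phenyl in place of 2-fluorophenyl shifts the number in this assay stays open, in either direction.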